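The compounds below may be only part of what the source reports. "The series", "measured", "known", "first", "only" and "open" are said of these compounds alone.

Three close relatives of compound 4 have been tested in a functional assay for inhibition, with Homo sapiens as the target; on this read-out higher numbers stand for weaker inhibition and lower numbers for stronger inhibition. Compound 1 `Cc1cn(-c2ccc(Nc3nccc(-c4ccncc4)n3)cc2)cn1` gives > 3000 nM, which is a limit of the assay and not a number. For the measured compounds named here, compound 2 `CC(=O)Nc1ccc(Nc2nccc(-c3cccnc3)n2)cc1` gives 3600 nM, and compound 3 `CC(=O)Nc1ccc(Nc2nccc(-c3ccccn3)n2)cc1` gives 1500 nM, the lower of the two actual numbers so far.

The next structure keeps the same atoms but joins them differently. Compound 4 `CC(=O)Nc1ccc(Nc2nccc(-c3ccncc3)n2)cc1` carries pyridin-4-yl in place of pyridin-2-yl on an aromatic carbon.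

Going by the values given here, only one measured step changes the same place, and it is a 2.4-fold lower number from compound 2 to compound 3 (0.38 log units; beyond the scatter), with pyridin-2-yl in place of pyridin-3-yl. That modest shift suggests that swapping one pyridine form for another moves the number only a little, so a step of similar size seems likely here. The direction is less certain, but compound 3 already has the lowest number, so a rise towards weaker inhibition in this assay is the more likely outcome. Compound 1 also carries pyridin-4-yl, though it differs elsewhere, and it sits at the limit of > 3000 nM in this assay, at which 1 of the 3 values shown sits, which fits that direction without proving it.

The expected change is a 1.9-fold higher number from compound 3 to compound 4 (0.27 log units; within the scatter). For compound 4 the estimated value is 2800 nM, with an expected range from 1000 nM to 8000 nM.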

Compound 4, half-maximal inhibitory concentration: 5300 nM
For compound 4 the middle estimate is 1.9-fold (0.28 log units) below the measured one; the measured number falls inside the stated range.
By their numbers in this assay, from the lowest: compound 3; then compounds 2 and 4 (each within the scatter of the next).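

In this assay all three pyridine forms now stand on the same core with the acetamido group unchanged, and the pyridin-2-yl form separates from pyridin-4-yl, with a 3.5-fold higher number from compound 3 to compound 4 (0.55 log units; beyond the scatter). The pyridin-3-yl and pyridin-4-yl forms, by contrast, cannot be told apart, with a 1.5-fold higher number from compound 2 to compound 4 (0.17 log units; within the scatter), so among these three compounds only pyridin-2-yl stands out, and compound 3 is the strongest inhibitor of the three. The step between compound 1, which carries 4-methyl-1H-imidazol-1-yl in place of acetamido, and compound 4 cannot be read, since compound 1 gives a limit and not a number: the limit of > 3000 nM in this assay, at which 1 of the 4 values shown sits.

From the compounds shown here alone, it remains open whether the lower number of compound 3 depends on a ring nitrogen at all, which a plain phenyl ring at this place would test. Going by these compounds, it is also open whether the same order of the pyridine forms holds when a different group, such as an amine or a carboxylic acid, stands in place of acetamido.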